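The source may hold more compounds than are shown below. What is called first, only, known or untested is meant among the compounds shown, and "the series" means these compounds.

Compound 1 `COc1cccc(-c2ncnn2-c2cc(OC)c(OC)c(OC)c2)c1` carries a 3-methoxyphenyl group on the shared core. In a functional assay on K562 cells (Homo sapiens) for antiproliferative activity, read by MTT assay, with a stated time of 72 h (a higher number here means a weaker inhibitor, a lower number a stronger inhibitor), compound 1 gives > 10000 nM, which is a limit of the assay and not a number, so compound 1 stands only at that limit among the values shown. Compound 2 `CCOc1cccc(-c2ncnn2-c2cc(OC)c(OC)c(OC)c2)c1` differs from compound 1 by methyl in place of hydrogen on a saturated chain carbon bound to an oxygen on an aromatic ring. In this assay compound 2 gives > 10000 nM, again a limit. That change yields a step that the two limits leave unreadable from compound 1 to compound 2. For the measured compounds named here, compound 3 `COc1ccc(-n2ncnc2-c2cc(OC)c(OC)c(OC)c2)cc1` gives 3600 nM in this assay; no single-place step joins it to compound 1, so its value serves only as a reference point. Compound 4 `COc1cc(-n2ncnc2-c2ccc(F)cc2)cc(OC)c1OC` differs from compound 1 as follows: 4-fluorophenyl in place of 3-methoxyphenyl on an aromatic carbon. Going by the values given here, no measured step bears on this change. Among the compounds with values here, the one step available is unreadable and concerns another place, and the limit of > 10000 nM in this assay, at which 2 of the 3 values shown sit, shows how little of the data is a real number. The expectation therefore rests on compound 1 alone, and the change a step that the limit leaves unreadable from compound 1 to compound 4 is expected to stay within the scatter, with a fair chance that only a limit is reported again. Compound 4 is estimated at 15000 nM, with a range from 3000 nM to 60000 nM.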

Compound 4, half-maximal inhibitory concentration: > 10000 nM
Compound 4: only a limit was reported; the forecaster's own chance of this, stated with the estimate: 60%; the middle value lies beyond the limit too.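

In this assay, for the compounds shown here, compound 4 gives > 10000 nM, a limit of the assay and not a number, and with compound 1 also at a limit, no step between the two can be read. The compounds shown leave open how far either swapped group changes the activity, because so few results are real numbers: the limit of > 10000 nM in this assay, at which 3 of the 4 values shown sit.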